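Swapping the benzyl substituent on a stable pair

The compounds below may be only part of what the source reports. "The series", "measured", "known", "first", "only" and "open" are said of these compounds alone.

Compound 1 `CS(=O)(=O)Nc1ccc2c(c1)S(=O)(=O)N=C(C1=C(O)[C@@H]3[C@@H]4CC[C@@H](C4)[C@@H]3N(Cc3ccccc3F)C1=O)N2`: 83%
Compound 2 `COc1cccc(CN2C(=O)C(C3=NS(=O)(=O)c4cc(NS(C)(=O)=O)ccc4N3)=C(O)[C@@H]3[C@@H]4CC[C@@H](C4)[C@@H]32)c1`: 83%

Both values come from an ADME assay on microsomes from liver (Homo sapiens) for metabolic stability, with a stated time of 60 min, tested at 1 uM (on this read-out lower numbers stand for a less stable compound and higher numbers for a more stable compound), and compound 2 stands level with compound 1, its nearest neighbour on these numbers. The next compound to be tested, compound 3 `CS(=O)(=O)Nc1ccc2c(c1)S(=O)(=O)N=C(C1=C(O)[C@@H]3[C@@H]4CC[C@@H](C4)[C@@H]3N(Cc3ccc(F)c(Cl)c3)C1=O)N2`, keeps the shared core and carries 3-chloro-4-fluorophenyl in place of 3-methoxyphenyl on a saturated chain carbon bound to an amide-type nitrogen in a ring. Going by the values given here, only one measured step bears on this change. It sits at the same place, where 3-methoxyphenyl replaced 2-fluorophenyl, and it reads no change at the digits printed from compound 1 to compound 2 (within the scatter). Among the compounds with values here, that is a single step, and no measured compound carries 3-chloro-4-fluorophenyl, so the support is thin and the range must stay wide. Even so, the one available comparison gives no reason to expect a real shift. The expected move is a number 3 percentage points lower from compound 2 to compound 3 (within the scatter), which is estimated to stay within the scatter and implies no firm direction. For compound 3 the estimate is 80%, with an expected range from 62% to 93% in this assay once it is measured.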

Compound 3, percent of the compound remaining: 100%
Estimate against measurement, compound 3: 20 percentage points below, and the stated range ends below it.
By their numbers in this assay, from the lowest: compounds 1 and 2 (each within the scatter of the next); then compound 3.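

At the place on a saturated chain carbon bound to an amide-type nitrogen in a ring, the aryl group does make a difference in this assay, which the earlier pair alone did not reveal: 3-chloro-4-fluorophenyl in place of 3-methoxyphenyl gives a number 17 percentage points higher from compound 2 to compound 3 (beyond the scatter), and 3-chloro-4-fluorophenyl in place of 2-fluorophenyl gives a number 17 percentage points higher from compound 1 to compound 3 (beyond the scatter), although the earlier swap had read no change at the digits printed from compound 1 to compound 2 (within the scatter). Compound 3 thus stands apart from both earlier compounds, its steps to each lying beyond the scatter, and the flat reading from the first pair does not extend to every group at this place. Nothing among the data offers a measured explanation for this rise.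

The compounds shown leave open whether the chlorine or the fluorine of 3-chloro-4-fluorophenyl would carry the step on its own, as each is seen here only in this one combination on the ring. They also leave open how the read-out would respond at this place to a pyridine ring, a carboxylic acid on the ring, or a longer chain to the amide-type nitrogen.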